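A few compounds are considered here, and "the series" means these few. Any claim that something is new, unique, unknown or untested is made for them only; others in the source may bear on it.

Compound 3 `CC(=O)NC[C@H]1CN(c2ccc(OC[C@@H](O)CNc3cccnc3)c(F)c2)C(=O)O1` stands lowest of the three compounds measured in a physicochemical assay for lipophilicity, read by HPLC; a higher number here means a more lipophilic compound, a lower number a more polar compound: compound 3 gives 0.02, while compound 1 `CC(=O)NC[C@H]1CN(c2ccc(OC[C@@H](O)CNc3ccccc3)c(F)c2)C(=O)O1` gives 1.42 and compound 2 `CC(=O)NC[C@H]1CN(c2ccc(OC[C@H](O)CNc3ccc(C#N)cc3)c(F)c2)C(=O)O1` gives 1.29. Among the compounds with values here, the one single-change step seen so far, a number 1.40 log units lower from compound 1 to compound 3 (beyond the scatter), concerns the ring on the amine nitrogen and does not touch the question now posed. Compound 4 `CC(=O)NC[C@H]1CN(c2ccc(OC[C@H](O)CNc3cccnc3)c(F)c2)C(=O)O1` differs from compound 3 only in configuration: the two compounds have the same atoms and bonds and differ only in configuration as drawn: 1 of 2 stereo elements differ; a stereocentre at a saturated chain carbon is drawn S in compound 3 and R in compound 4. Within the data shown here, no measured step isolates such a change; compounds 1 and 2 differ in that centre but also in the nitrile, and their values lie within the scatter of each other. For compound 4 no step beyond the scatter is therefore expected, no change at the digits printed from compound 3 to compound 4 (within the scatter), giving an estimate of 0.02 with a range from -0.28 to 0.32.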

Compound 4, partition coefficient: -0.18
The estimate for compound 4 lay 0.20 log units above the measured number, and the stated range covers the measured number.
By their numbers in this assay, from the lowest: compounds 4 and 3 (each within the scatter of the next); then compounds 2 and 1 (each within the scatter of the next).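

In this assay, within the data shown here, the drawn S-to-R switch at the saturated chain carbon gives a number 0.20 log units lower from compound 3 to compound 4 (within the scatter), the first reading of this stereocentre with the ring on the amine nitrogen held constant: the fact that compounds 3 and 4 differ only in the configuration as drawn. With the R centre kept, pyridin-3-yl in place of 4-cyanophenyl gives a number 1.47 log units lower from compound 2 to compound 4 (beyond the scatter), a step confined to the ring. The remaining step, a number 1.60 log units lower from compound 1 to compound 4 (beyond the scatter), combines the ring change with the stereocentre change.

The compounds shown leave open whether S and R forms also stay within the scatter when the ring is phenyl, 4-cyanophenyl or a phenyl ring bearing a carboxylic acid.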